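Working notes on compound 3 of the shared core

This account rests on a few compounds, and the source may have more. Where it says the series, first, only, none or still open, it means among the compounds named here.

Two compounds of the shared core have numbers in a functional assay (Homo sapiens), tested at 10 uM; on this read-out lower numbers stand for a stronger effect and higher numbers for a weaker effect at the one concentration tested. Compound 1 `CS(=O)(=O)c1ccc(CCCC(=O)N2CCc3c(Cl)c(O)c(O)c(Cl)c3C2)nc1` gives 72%. Compound 2 `O=C(/C=C/c1cccnc1)N1CCc2c(Cl)c(O)c(O)c(Cl)c2C1` gives 44%, the lower of the two numbers; the nearest is compound 1, whose number is higher by a margin beyond the scatter. Among the measured compounds shown here, no measured pair differs in a single place, so the two values show only that compound 2 acts more strongly than compound 1 at the one concentration tested.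

Compound 3 `O=C(/C=C/c1ccc(F)cn1)N1CCc2c(Cl)c(O)c(O)c(Cl)c2C1` differs from compound 2 in one place: 5-fluoropyridin-2-yl in place of pyridin-3-yl on a double-bonded chain carbon bound to a double-bonded chain carbon. For the measured compounds named here, the measured compounds give no step of this kind, so size and direction are open. A step within the scatter, or a small move toward a higher number, is expected, and the estimated step of a number 8 percentage points higher from compound 2 to compound 3 (within the scatter) is kept modest. Compound 3 is expected to give about 52% in this assay, between 35% and 72%.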

Compound 3, a percentage reported as activity, at one concentration (the size of the read-out at that concentration, not a potency): 24%
Compound 3: the middle estimate sits 28 percentage points above what was measured; measured number outside the range, below it.
By their numbers in this assay, from the lowest: compound 3; then compound 2; then compound 1.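

At the position on a double-bonded chain carbon bound to a double-bonded chain carbon, the identity of the ring matters in this assay: 5-fluoropyridin-2-yl in place of pyridin-3-yl gives a number 20 percentage points lower from compound 2 to compound 3 (beyond the scatter). Among the compounds shown here, this is the only single-place step so far, and it shows that this position responds to a change of ring, with 5-fluoropyridin-2-yl giving the stronger effect at the one concentration tested. No measured evidence bears on what lies behind this step.

The compounds shown do not separate the fluorine from the change in how the pyridine ring is attached; a plain pyridin-2-yl group would tell these apart. Also open, as far as these compounds go, is how the read-out responds to a phenyl ring or a carboxylic acid at this position.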